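This account rests on a few compounds, and the source may have more. Where it says the series, first, only, none or still open, it means among the compounds named here.

Measured in an ADME assay on HUVEC cells (Homo sapiens) for inhibition, read by CCK-8 assay, with a stated time of 24 h, in the presence of a further agent that is not named here; on this read-out lower numbers stand for stronger inhibition and higher numbers for weaker inhibition:
- compound 1 `Cc1ccccc1-n1cc(-c2ccc(/C=C3\C(=O)Nc4ccccc43)cc2)nn1`: 14700 nM
- compound 2 `Cc1ccccc1-n1cc(-c2ccc(C=C3C(=O)Nc4ccc(F)cc43)cc2)nn1`: 8630 nM
- compound 3 `Cc1ccc(-n2cc(-c3ccc(/C=C4\C(=O)Nc5ccc(F)cc54)cc3)nn2)cc1`: 13800 nM

Compound 3 lies within the usual scatter of both compound 1 and compound 2, so its number cannot be firmly separated from either. No two of these three compounds differ in just one place, so none of them shows what a single change does.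

The next compound, compound 4 `O=C1Nc2ccc(F)cc2/C1=C/c1ccc(-c2cn(-c3ccc(Cl)c(C(F)(F)F)c3)nn2)cc1`, keeps the core of compound 3 but carries 4-chloro-3-(trifluoromethyl)phenyl in place of 4-methylphenyl on an aromatic nitrogen. For the measured compounds named here, no measured pair tests this swap, so the expectation starts from compound 3 at 13800 nM and stays cautious. A modest move towards stronger inhibition in this assay is expected, possibly no larger than the scatter. The estimated step is a 1.8-fold lower number from compound 3 to compound 4 (0.26 log units; within the scatter). For compound 4 the estimated value is 7500 nM, with an expected range from 2800 nM to 20000 nM.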

Compound 4, half-maximal inhibitory concentration: > 20000 nM
Compound 4: no number, only a limit; the forecaster's own chance of this, stated with the estimate: 10%; middle value at least 2.6-fold (0.42 log units) away from the limit.
By their numbers in this assay, from the lowest: compounds 2, 3 and 1 (each within the scatter of the next). At a limit, above all of these: compound 4.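

In this assay, compound 4 gives > 20000 nM, which is a limit of the assay and not a number. This is the first change in one place among these compounds: 4-chloro-3-(trifluoromethyl)phenyl in place of 4-methylphenyl on an aromatic nitrogen gives an at least 1.4-fold higher number from compound 3 to compound 4 (0.16 log units; that floor lies within the scatter). The swap therefore brings no sign of stronger inhibition at this position, but only a floor for the step can be read, not its true size: the limit of > 20000 nM in this assay, at which 1 of the 4 values shown sits.

On these data alone, the chlorine and the trifluoromethyl group enter together, so what each does alone stays open, and a phenyl ring carrying only one of them would be needed to separate them. Also open, as far as these compounds go, is how an amine or a carboxylic acid on this phenyl ring would read.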